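Amide-nitrogen substitution on the shared core, step to compound 4

The compounds below may be only part of what the source reports. "The series", "measured", "known", "first", "only" and "open" are said of these compounds alone.

Measured compounds in an in vitro assay on Sf21 cells for inhibition of high affinity 3',5'-cyclic-AMP phosphodiesterase 7A (Homo sapiens), read by scintillation proximity assay, with a stated time of 30 min; on this read-out lower numbers stand for stronger inhibition and higher numbers for weaker inhibition:
compound 1, `O=C(Nc1ccccc1)c1cn(Cc2c(F)cccc2F)c2ccc(=O)[nH]c2c1=O`, 94 nM
compound 2, `O=C(Nc1c(F)cccc1F)c1cn(Cc2c(F)cccc2F)c2ccc(=O)[nH]c2c1=O`, > 1000 nM
compound 3, `O=C(O)Cc1ccc(NC(=O)c2cn(Cc3c(F)cccc3F)c3ccc(=O)[nH]c3c2=O)cc1`, 176 nM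

Compound 1 has the lowest number among the two numbers recorded in this assay. Compound 3 is nearest, and the step of a 1.9-fold higher number from compound 1 to compound 3 (0.27 log units; within the scatter) stays within the scatter. The value of compound 2 is a limit of this assay, not a number (the limit of > 1000 nM in this assay, at which 1 of the 3 values shown sits); the step of an at least 10-fold higher number from compound 1 to compound 2 (1.02 log units; beyond the scatter) is large, and the step of an at least 5.6-fold lower number from compound 2 to compound 3 (0.75 log units; beyond the scatter) is at least modest.

Compound 4, `O=C(Nc1ccc(C(=O)N2CCOCC2)cc1)c1cn(Cc2c(F)cccc2F)c2ccc(=O)[nH]c2c1=O`, is not yet measured. It differs from compound 1 by (morpholin-4-yl)carbonyl in place of hydrogen on an aromatic carbon. The closest measured precedent is compound 3, where carboxymethyl enters the same kind of aromatic carbon of the amide-nitrogen ring, and that step is within the scatter. The change in compound 2 is of a different kind, on the ring positions flanking the amide nitrogen, and does not bear directly on compound 4.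

For compound 4 the expected step is therefore a 1.6-fold higher number from compound 1 to compound 4 (0.20 log units; within the scatter), a small shift that need not exceed the scatter. Compound 4 is estimated at 150 nM, with a range from 60 nM to 400 nM.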

Compound 4, half-maximal inhibitory concentration: 188 nM
Compound 4: middle estimate off by 1.3-fold (0.10 log units), on the low side, and the stated range covers the measured number.
By their numbers in this assay, from the lowest: compounds 1, 3 and 4 (each within the scatter of the next). At a limit, above all of these: compound 2.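

In this assay, the step to (morpholin-4-yl)carbonyl on the aromatic carbon para to a large group is a 2.0-fold higher number from compound 1 to compound 4 (0.30 log units; within the scatter), so a group of 8 heavy atoms with a six-membered non-aromatic ring is accommodated at this position without a change that can be told from the scatter. Exchanging carboxymethyl for this group gives a 1.1-fold higher number from compound 3 to compound 4 (0.03 log units; within the scatter), which means that two different groups at this position, one with a ring and one without, give values that cannot be told apart. The data shown hold no measurement that offers a reason for this result.

On these data alone, how a carboxylic acid set directly on the ring, an amine, or a longer chain carrying the morpholine would behave at this same carbon remains open. Also open, as far as these compounds go, is whether any group here can lower the number beyond the scatter of compound 1.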